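This account rests on a few compounds, and the source may have more. Where it says the series, first, only, none or still open, it means among the compounds named here.

Measured compounds in the series:

- compound 1, `Cc1ccc(-c2c(N)n[nH]c2C)cc1C`; in an assay on Sf9 cells for inhibition of mitogen-activated protein kinase kinase kinase 14 (Homo sapiens), read by ADP-Glo, with a stated time of 60 min (a lower number here means a stronger inhibitor, a higher number a weaker inhibitor), compound 1 gives > 100000 nM, which is a limit of the assay and not a number.
- compound 2, `CCC(=O)n1nc(C)c(-c2ccc(Cl)c(Cl)c2)c1N`; in this assay compound 2 gives 27400 nM.
- compound 3, `Cc1nn(C(=O)C2CCC2)c(N)c1-c1ccc(Cl)c(Cl)c1`; in this assay compound 3 gives 2900 nM.

For the measured compounds named here, compound 3 holds the lowest of the two numbers given; its nearest neighbour is compound 2, and the single measured step goes a 9.4-fold lower number from compound 2 to compound 3 (0.98 log units; beyond the scatter). Compound 1 sits at the limit of > 100000 nM in this assay, at which 1 of the 3 values shown sits, and gives no number to compare.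

The next compound is compound 4, `Cc1nn(C(=O)c2cccnc2)c(N)c1-c1ccc(Cl)c(Cl)c1`. It differs from compound 3 in one place: pyridin-3-yl in place of cyclobutyl on a carbonyl carbon.

Going by the values given here, only one measured step touches the group on the carbonyl carbon, a 9.4-fold lower number from compound 2 to compound 3 (0.98 log units; beyond the scatter), and it exchanged one group without an aromatic ring for another. Among the compounds with values here, no measured step swaps in an aromatic ring at this position, so that step bears on the present change only loosely. The expected change is therefore small, a 1.5-fold lower number from compound 3 to compound 4 (0.16 log units; within the scatter), possibly within the scatter. For compound 4 in this assay the estimate is 2000 nM, with a range from 400 nM to 9000 nM.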

Compound 4, half-maximal inhibitory concentration: > 100000 nM
Compound 4 ended at the assay's limit; the forecaster's own chance of this, stated with the estimate: 5%; at least 50-fold (1.69 log units) between middle value and limit.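

Compound 4 gives > 100000 nM in this assay, which is a limit of the assay and not a number. Pyridin-3-yl in place of cyclobutyl on the carbonyl carbon gives an at least 34-fold higher number from compound 3 to compound 4 (1.53 log units; beyond the scatter), and pyridin-3-yl in place of ethyl gives an at least 3.6-fold higher number from compound 2 to compound 4 (0.56 log units; beyond the scatter). The position is therefore sensitive to the kind of group: the gain in a 9.4-fold lower number from compound 2 to compound 3 (0.98 log units; beyond the scatter) does not carry over to this aromatic ring, which falls behind both groups without an aromatic ring.

As far as these compounds go, whether the loss follows the aromatic ring, its ring nitrogen or the ring size stays open, and phenyl or cyclohexyl on the carbonyl carbon would bear on that question. The full size of both new steps also stays open: the limit of > 100000 nM in this assay, at which 2 of the 4 values shown sit.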